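Swapping Methyl for Fluoro on the Sulfonyl Aryl Ring

A few compounds are considered here, and "the series" means these few. Any claim that something is new, unique, unknown or untested is made for them only; others in the source may bear on it.

Three compounds have been measured in a functional assay on HCT-116 cells (Homo sapiens) for antiproliferative activity, read by MTT assay, with a stated time of 72 h; a lower number here means a stronger inhibitor, a higher number a weaker inhibitor:
- compound 1, `COc1c(NS(=O)(=O)C2CC2)cc(-c2ccc3nc(NC(C)=O)nn3c2)cc1C(N)=O`, gives 36300 nM
- compound 2, `COc1c(NS(=O)(=O)c2ccc(F)cc2)cc(-c2ccc3nc(NC(=O)C4CC4)nn3c2)cc1C(N)=O`, gives 43500 nM
- compound 3, `COc1c(NS(=O)(=O)c2ccc(C)cc2)cc(-c2ccc3nc(NC(C)=O)nn3c2)cc1C(N)=O`, gives 27300 nM

On paper compound 3 carries the lowest of the three numbers, but its gaps to compound 1 and to compound 2 both fall within the usual scatter, so no ranking follows from these values. For the measured compounds named here, the one single-point step measured so far, a 1.3-fold lower number from compound 1 to compound 3 (0.12 log units; within the scatter), also stays within the scatter; exchanging the whole group on the sulfonyl sulfur moved the read-out hardly at all.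

Compound 4, `COc1c(NS(=O)(=O)c2ccc(F)cc2)cc(-c2ccc3nc(NC(C)=O)nn3c2)cc1C(N)=O`, differs from compound 3 in one spot: fluoro in place of methyl on an aromatic carbon. Going by the values given here, no measured step covers this exact exchange. The closest pointer is compound 2, which carries the same (4-fluorophenyl)sulfonyl group but a different amide, and compound 2 gives 43500 nM, again within the scatter of the others.

Among the compounds with values here, with every measured step so far small, the expected step of a 1.3-fold higher number from compound 3 to compound 4 (0.11 log units; within the scatter) is no more than the scatter. Compound 4 is therefore estimated at 35000 nM, with a range from 15000 nM to 80000 nM.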

Compound 4, half-maximal inhibitory concentration: 25400 nM
Beside the measured number, compound 4's estimate is 1.4-fold (0.14 log units) above it; low and high end bracket the measured number.
By their numbers in this assay, from the lowest: compounds 4, 3, 1 and 2 (each within the scatter of the next).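

In this assay, the exchange at this position, on an aromatic carbon para to a large group, now has a direct reading (a 1.1-fold lower number from compound 3 to compound 4 (0.03 log units; within the scatter)), and that step stays within the scatter, so fluoro and methyl cannot be told apart here. The two other new steps, one on the sulfonyl sulfur (a 1.4-fold lower number from compound 1 to compound 4 (0.16 log units; within the scatter)) and one on the carbonyl carbon (a 1.7-fold lower number from compound 2 to compound 4 (0.23 log units; within the scatter)), also stay within the scatter, so neither of these single changes separates the compounds in this read-out. Nothing measured here bears on why these exchanges leave the number in place.

On these data alone, whether this position can respond at all stays open, as an amine, a carboxylic acid or a longer chain in place of fluoro or methyl lies outside these compounds. Also open, as far as these compounds go, is which change to the shared core, if any, would move the read-out beyond the scatter.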